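Anilino for ethoxy: second application of one change

The source may report more compounds than this note shows. Statements on the series, on what has been measured and on what is new or still open speak of the compounds shown alone.

Compound 1 `CCOC(=O)C1=C(C)NC(=O)NC1c1cn(-c2ccccc2)nc1-c1ccccc1` and compound 2 `CC1=C(C(=O)Nc2ccccc2)C(c2cn(-c3ccccc3)nc2-c2ccccc2)NC(=O)N1` share one core and differ at a single place. In a functional assay on MCF7 cells (Homo sapiens) for inhibition, read by sulforhodamine B assay, with a stated time of 24 h (a lower number here means a stronger inhibitor of growth, a higher number a weaker inhibitor of growth), compound 1 gives 60800 nM, and compound 2 gives 80600 nM. The change between them, (anilino in place of ethoxy on a carbonyl carbon), produced a 1.3-fold higher number from compound 1 to compound 2 (0.12 log units; within the scatter). Compound 3 `CCOC(=O)C1=C(C)NC(=S)NC1c1cn(-c2ccccc2)nc1-c1ccc(Cl)cc1` sits on a different core; how the two cores differ is not broken down here. In this assay compound 3 gives 33200 nM, the lowest of the three numbers, with the gap to compound 1 within the scatter and the gap to compound 2 beyond it. Compound 4 `CC1=C(C(=O)Nc2ccccc2)C(c2cn(-c3ccccc3)nc2-c2ccc(Cl)cc2)NC(=S)N1` has not yet been measured. It differs from compound 3 by anilino in place of ethoxy on a carbonyl carbon, the same change as that from compound 1 to compound 2, made at a place described in identical words. For the measured compounds named here, only one earlier instance of this change is known, so the expectation for compound 4 rests on that single step: a step of about a 1.3-fold higher number from compound 3 to compound 4 (0.11 log units; within the scatter) is expected, because the earlier instance gave a 1.3-fold higher number from compound 1 to compound 2 (0.12 log units; within the scatter). In this assay compound 4 is therefore estimated at 43000 nM, with a likely range from 20000 nM to 95000 nM.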

Compound 4, concentration for 50% growth inhibition: 61500 nM
Compound 4: the middle estimate sits 1.4-fold (0.16 log units) below what was measured, within the range that was stated.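

Anilino in place of ethoxy on a carbonyl carbon, carried onto the core of compound 3, gives in this assay a 1.9-fold higher number from compound 3 to compound 4 (0.27 log units; within the scatter). Set beside the earlier step, the change reads the same on both cores within the scatter: the same change on two cores in this assay, a 1.3-fold higher number (0.12 log units; within the scatter) from compound 1 to compound 2 and a 1.9-fold higher number (0.27 log units; within the scatter) from compound 3 to compound 4, 1.4-fold (0.15 log units) apart, within the scatter of two such steps. For the compounds shown here, this shows only that neither step can be told from repeat-measurement scatter and that the two cores give no detectable difference in the effect of the change; it does not show a real effect of the change on growth inhibition, nor that the same step would hold on any core beyond these two.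

The compounds shown leave open what other groups do on this carbonyl carbon, such as a carboxylic acid, a small amine like methylamino, or a longer alkoxy chain such as butoxy. Also open, on these data alone, is whether a substituted anilino, for example one bearing a methoxy group, would move the number beyond the scatter on either core.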